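From Ethyl to Phenyl: A Step Still Unmeasured

The source may hold more compounds than are shown below. What is called first, only, known or untested is meant among the compounds shown, and "the series" means these compounds.

In an ADME assay on liver (Rattus norvegicus) for activation, read by HPLC (a higher number here means that the compound lasts longer, a lower number that the compound disappears faster), compound 1 (`CCOC(=O)NCCCC(C)Nc1cc(OC)cc2cccnc12`) gives 15.1 h and compound 2 (`COc1cc(NC(C)CCCNC(=O)OCC(F)(F)F)c2ncccc2c1`) gives 13.7 h, so the two stand level within the scatter. Compound 3 (`COc1cc(NC(C)CCCNC(=O)Oc2ccccc2)c2ncccc2c1`) carries phenyl in place of ethyl on an oxygen next to a carbonyl group. Going by the values given here, the one measured step bearing on this also alters the group on that oxygen, and it was small (a 1.1-fold lower number from compound 1 to compound 2 (0.04 log units; within the scatter)). No ring entered there, so it is a weak guide, and a modest drop is expected (a 1.5-fold lower number from compound 1 to compound 3 (0.18 log units; within the scatter)). For compound 3 the estimated half-life is 10 h, with 4 h to 20 h as the expected range.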

Compound 3, half-life: 9.5 h
Beside the measured number, compound 3's estimate is 1.1-fold (0.02 log units) above it; the range from low to high includes it.
By their numbers in this assay, from the lowest: compounds 3, 2 and 1 (each within the scatter of the next).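

Swapping the open chain for a ring on this oxygen next to a carbonyl group, where phenyl replaces ethyl, leaves the compounds inseparable in this assay (a 1.6-fold lower number from compound 1 to compound 3 (0.20 log units; within the scatter)). Phenyl in place of 2,2,2-trifluoroethyl gives the same picture (a 1.4-fold lower number from compound 2 to compound 3 (0.16 log units; within the scatter)), so the three groups shown at this place all stand within the scatter of one another. Nothing available explains this result. Open, on these data alone, is whether a longer chain, or a chain ending in an amine, on this oxygen would move the half-life beyond the scatter.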